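A few compounds are considered here, and "the series" means these few. Any claim that something is new, unique, unknown or untested is made for them only; others in the source may bear on it.

Of the compounds shown here, three built on one shared core have been tested in a functional assay on the whole organism (Tail, strain ICR) with Mus musculus as the target, in the tail flick test, with a stated time of 60 min, at a dose of 25 umol/kg by the oral route; on this read-out lower numbers stand for a weaker effect and higher numbers for a stronger effect at the one dose given. Compound 1 `O=C(CN(c1nc(Cl)nc2[nH]cnc12)C1CC1)NCC(=O)OCc1ccccc1` gives 41.9%. Compound 2 `N=C(N)NCCC[C@H](NC(=O)CN(c1nc(Cl)nc2[nH]cnc12)C1CC1)C(=O)O` gives 51%, and compound 3 `CC[C@H](C)[C@H](NC(=O)CN(c1nc(Cl)nc2[nH]cnc12)C1CC1)C(=O)O` gives 36%. On these numbers compound 3 shows the smallest of the three, though its separation from compound 1 lies within the scatter and only compound 2 stands beyond it. Among the compounds with values here, the single step measured in one place is a number 15 percentage points lower from compound 2 to compound 3 (beyond the scatter), a modest fall.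

Compound 4 `O=C(O)CNC(=O)CN(c1nc(Cl)nc2[nH]cnc12)C1CC1` has not yet been measured in this assay. It differs from compound 3 in one place, (hydrogen in place of sec-butyl on a saturated chain carbon bound to an amide-type nitrogen and a carbonyl carbon). Within the data shown here, the only measured step that touches this place is the one from compound 2 to compound 3, which replaced a larger group with sec-butyl and was modest; it gives no direct guide to removing the sec-butyl altogether. Since compound 1 and compound 2 sit on either side of compound 3 by amounts close to the scatter, no step beyond the scatter is expected for compound 4, a number 4 percentage points higher from compound 3 to compound 4 (within the scatter). Compound 4 is therefore estimated at 40%, within a range from 25% to 56%.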

Compound 4, a percentage reported as activity, at one dose (the size of the read-out at that dose, not a potency): 38.9%
The estimate for compound 4 lay 1.1 percentage points above the measured number; low and high end bracket the measured number.
By their numbers in this assay, from the lowest: compounds 3, 4, 1 and 2 (each within the scatter of the next, the first and the last beyond it).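

In this assay, hydrogen in place of sec-butyl on a saturated chain carbon bound to an amide-type nitrogen and a carbonyl carbon gives a number 2.9 percentage points higher from compound 3 to compound 4 (within the scatter) and so shows that this group can be removed without a difference that stands clear of the scatter. Within the data shown here, at the same place, hydrogen in place of the group of 7 heavy atoms gives a number 12.1 percentage points lower from compound 2 to compound 4 (beyond the scatter) and so shows that, of the two groups compared with hydrogen here, only the one in compound 2 gives a difference beyond the scatter. At a second place, hydrogen in place of benzyl on an oxygen next to a carbonyl group gives a number 3 percentage points lower from compound 1 to compound 4 (within the scatter) and so leaves the two compounds indistinguishable on this read-out at this one dose.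

No supporting measurement explains what sets compound 2 apart. The compounds shown leave open whether a plain amine at the end of the chain, or a longer carbon chain without nitrogen, would give a number like that of compound 2 or one like that of compound 4.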